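A ketone side chain on a compound at the limit

A few compounds are considered here, and "the series" means these few. Any claim that something is new, unique, unknown or untested is made for them only; others in the source may bear on it.

In a functional assay on HepG2 cells (Homo sapiens) for inhibition, read by MTT assay, with a stated time of 48 h (on this read-out higher numbers stand for weaker inhibition and lower numbers for stronger inhibition), compound 1 (`COc1ccc(-n2c(SCc3ccc(C)cc3)nnc2-c2cc(OC)c(OC)c(OC)c2)cc1`) gives 31600 nM and compound 2 (`COc1ccc(C(=O)CSc2nnc(-c3cc(OC)c(OC)c(OC)c3)n2-c2ccc(OC)cc2)cc1`) gives 18100 nM as numbers. Compound 3 (`COc1cc(-c2nnc(SCc3ccc(C)cc3)n2-c2ccc(N(C)C)cc2)cc(OC)c1OC`) has no number, only the limit > 60000 nM and thus sits at the limit of > 60000 nM in this assay, at which 1 of the 3 values shown sits, with no firmer placing. Compound 4 (`COc1cc(-c2nnc(SCC(=O)C3CC3)n2-c2ccc(N(C)C)cc2)cc(OC)c1OC`) has cyclopropylcarbonyl in place of 4-methylphenyl on a saturated chain carbon bound to a sulfur. The closest measured change is a 1.7-fold lower number from compound 1 to compound 2 (0.24 log units; within the scatter) for (4-methoxyphenyl)carbonyl at that place. The other relevant step is an at least 1.8-fold higher number from compound 1 to compound 3 (0.27 log units; that floor lies within the scatter) for dimethylamino in place of methoxy on an aromatic carbon. A small fall in the number, near the scatter, is therefore expected in this assay and no large gain. The expected step is an at least 1.5-fold lower number from compound 3 to compound 4 (0.17 log units; that floor lies within the scatter) at most modest in size. Compound 4 is estimated at 40000 nM within an expected range of 15000 nM to 85000 nM and may also return only a limit.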

Compound 4, half-maximal inhibitory concentration: > 60000 nM
Compound 4 gave a limit, no number; the forecaster's own chance of this, stated with the estimate: 40%; middle value at least 1.5-fold (0.17 log units) away from the limit.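

Compound 3 and compound 4 both give only a limit in this assay, so no step between them can be read: the limit of > 60000 nM in this assay, at which 2 of the 4 values shown sit.

The compounds shown leave open whether cyclopropylcarbonyl in place of 4-methylphenyl changes inhibition at all.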